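The source may report more compounds than this note shows. Statements on the series, on what has been measured and on what is new or still open speak of the compounds shown alone.

Going by the values given here, compound 2 `COc1ccc2[nH]c3c(c2c1)CCNC31CCN(Cc2ccccc2Cl)CC1` sits at the lower of the two numbers measured so far in an assay on FRT cells for positive allosteric modulation of Cystic fibrosis transmembrane conductance regulator variant N1303K (Homo sapiens), in the presence of a further agent that is not named here; on this read-out higher numbers stand for an effect only at larger amounts of compound and lower numbers for an effect already at smaller amounts: compound 2 gives 2200 nM, while compound 1 `COc1ccc2[nH]c3c(c2c1)CCNC31CCN(Cc2ccccc2)CC1` gives 12600 nM. Among the compounds with values here, the one step that connects them, a 5.7-fold lower number from compound 1 to compound 2 (0.76 log units; beyond the scatter), is the only measured step in this small set.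

Compound 3 `COc1ccc2[nH]c3c(c2c1)CCNC31CCN(Cc2ccc(F)cc2F)CC1` differs from compound 2 by a single change: 2,4-difluorophenyl in place of 2-chlorophenyl on a saturated chain carbon bound to an amine nitrogen in a ring. Within the data shown here, no measured pair shows this exact exchange. The step from compound 1 to compound 2 only shows that placing one halogen on that ring changed the number beyond the scatter; it says nothing about swapping one halogen for two different ones. Among the measured compounds shown here, with only that step to lean on, the expectation is a number near compound 2, perhaps somewhat higher, with a 1.6-fold higher number from compound 2 to compound 3 (0.20 log units; within the scatter) the expected step. The estimated value for compound 3 in this assay is therefore 3500 nM, within a range from 1200 nM to 10000 nM.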

Compound 3, half-maximal effective concentration: 2000 nM
Compound 3: middle estimate off by 1.8-fold (0.24 log units), on the high side, within the range that was stated.
By their numbers in this assay, from the lowest: compounds 3 and 2 (each within the scatter of the next); then compound 1.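

In this assay, the exchange of 2-chlorophenyl for 2,4-difluorophenyl gives a 1.1-fold lower number from compound 2 to compound 3 (0.04 log units; within the scatter), so at this place, on a saturated chain carbon bound to an amine nitrogen in a ring, these two halogen-bearing rings cannot be told apart. Set against plain phenyl, 2,4-difluorophenyl gives a 6.3-fold lower number from compound 1 to compound 3 (0.80 log units; beyond the scatter), so the difference from compound 1 is no longer tied to chlorine alone, as a ring carrying fluorine instead also stands apart from it. No information is given that would account for either result.

From the compounds shown here alone, it remains open whether one fluorine alone, as in 2-fluorophenyl or 4-fluorophenyl, would match compound 3. Also open, going by these compounds, is whether a ring carrying no halogen at all, such as one bearing a methoxy or a nitrile group, would stand with compound 2 and compound 3 or with compound 1.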